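Benzyl carbamate analogue in the growth-inhibition series

The source may report more compounds than this note shows. Statements on the series, on what has been measured and on what is new or still open speak of the compounds shown alone.

compound 1 `CCCOC(=O)Nc1ccc([Se]C#N)cc1` 28900 nM
compound 2 `CCOC(=O)Nc1ccc([Se][Se]c2ccc(NC(=O)OCC)cc2)cc1` 31200 nM

In a functional assay on HTB-54 cells (Homo sapiens) for cytotoxicity, read by MTT assay, with a stated time of 72 h (a higher number here means a weaker inhibitor of growth, a lower number a stronger inhibitor of growth), compound 1 gives 28900 nM. Compound 2 gives 31200 nM, and the two numbers lie within the scatter of each other, so neither compound can be called the stronger. Compound 3 `N#C[Se]c1ccc(NC(=O)OCc2ccccc2)cc1` differs from compound 1 by phenyl in place of ethyl on a saturated chain carbon bound to an oxygen next to a carbonyl group. Among the compounds with values here, no measured pair shows this change, so its effect in this assay is unknown. The step from compound 1 to compound 3 is expected to be small, at most a modest move toward a lower number and possibly none beyond the scatter, as a 1.6-fold lower number from compound 1 to compound 3 (0.21 log units; within the scatter). Compound 3 is estimated at 18000 nM in this assay, with a range from 6000 nM to 50000 nM.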

Compound 3, concentration for 50% growth inhibition: 27600 nM
The estimate for compound 3 lay 1.5-fold (0.19 log units) below the measured number; measured number inside the range.
By their numbers in this assay, from the lowest: compounds 3, 1 and 2 (each within the scatter of the next).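

Phenyl in place of ethyl on a saturated chain carbon bound to an oxygen next to a carbonyl group gives a step in this assay that stays within the scatter (a 1.0-fold lower number from compound 1 to compound 3 (0.02 log units; within the scatter)). This position therefore accepts one six-membered aromatic ring of carbon only, with six heavy atoms in place of two, without a readable shift in growth inhibition. No available measurement accounts for this outcome.

From the compounds shown here alone, whether a longer chain or an amine at this carbon would also leave the number unmoved remains open. So does the effect of a carboxylic acid on the phenyl ring.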